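Series notes: methoxy removal on the aromatic ring, compound 4

The compounds below may be only part of what the source reports. "The series", "measured", "known", "first", "only" and "open" are said of these compounds alone.

Measured compounds in a functional assay on A549 cells (Homo sapiens) for cytotoxicity, read by crystal violet staining, with a stated time of 72 h; a lower number here means a stronger inhibitor, a higher number a weaker inhibitor:
- compound 1 `COc1cc(/C=C/C(=O)/C=C(O)/C=C/c2ccc(O[C@H]3C=C(C)[C@@H](O)C[C@@H]3[C@@H](C)CCC=C(C)C)c(OC)c2)ccc1O`: 30600 nM
- compound 2 `COc1cc(/C=C/C(=O)/C=C(O)/C=C/c2ccc(O[C@]3(C)C=C[C@@H]([C@@H](C)CC(=O)C=C(C)C)C[C@@H]3O)c(OC)c2)ccc1O`: 15200 nM
- compound 3 `COc1cc(/C=C/C(=O)/C=C(O)/C=C/c2ccc(O[C@H]3C=C(C)[C@@H](O)C[C@@H]3[C@@H](C)CC(=O)C=C(C)C)c(OC)c2)ccc1O`: 16100 nM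

Compound 3 holds the second highest of the three numbers. Its nearest neighbour is compound 2, and the gap between the two is within the scatter; compound 1 lies furthest from it, and that gap, the step of a 1.9-fold lower number from compound 1 to compound 3 (0.28 log units; within the scatter), is also within the scatter. Within the data shown here, the single step measured so far, from compound 1 to compound 3, exchanges groups on the saturated chain and leaves the aromatic rings untouched.

Compound 4 `COc1cc(/C=C/C(O)=C/C(=O)/C=C/c2ccc(O)cc2)ccc1O[C@H]1C=C(C)[C@@H](O)C[C@@H]1[C@@H](C)CC(=O)C=C(C)C` differs from compound 3 on one of the aromatic rings: hydrogen in place of methoxy on an aromatic carbon. Among the measured compounds shown here, no measured step in this set touches that ring, so there is no direct guide for the change; the only measured step, on the chain, stayed within the scatter. On that basis no step beyond the scatter is expected for a 1.0-fold lower number from compound 3 to compound 4 (0.00 log units; within the scatter), and the estimate takes the number of compound 3 as its centre, with a wider range to allow for the untested position.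

Compound 4 is expected to give about 16000 nM in this assay, within a range of 6000 nM to 45000 nM.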

Compound 4, half-maximal inhibitory concentration: 16600 nM
Estimate against measurement, compound 4: 1.0-fold (0.02 log units) below; low and high end bracket the measured number.
By their numbers in this assay, from the lowest: compounds 2, 3, 4 and 1 (each within the scatter of the next).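

In this assay, among these compounds, replacing 4-hydroxy-3-methoxyphenyl with 4-hydroxyphenyl gives a 1.0-fold higher number from compound 3 to compound 4 (0.01 log units; within the scatter), the first reading for a change on an aromatic ring. The methoxy group on this aromatic carbon, ortho to a hydroxy group, can therefore be exchanged for hydrogen without a step beyond the scatter, whereas the earlier step covered only the saturated chain. Nothing available explains why this exchange leaves the number within the scatter.

Open questions are whether a group larger than methoxy, such as ethoxy or benzyloxy, or a different type of group, such as an amine or a chlorine atom, would give a step beyond the scatter at this aromatic carbon. Also open, as far as these compounds go, are whether the methoxy group on the other aromatic ring can be exchanged for hydrogen in the same way, and whether the two exchanges together would stay within the scatter of compound 3.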